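Chloro for bromo on the anilide of compound 1

The source may hold more compounds than are shown below. What is called first, only, known or untested is meant among the compounds shown, and "the series" means these compounds.

Compound 1 `CC(C)[C@H](NC(=O)c1ccc(Cl)cc1O)C(=O)Nc1ccc(Br)cc1` is known only as a limit: in a functional assay on K562 cells (Homo sapiens) for cytotoxicity, with a stated time of 72 h (on this read-out higher numbers stand for weaker inhibition and lower numbers for stronger inhibition), compound 1 gives > 10000 nM, a limit of the assay and not a number. Compound 2 `CC(C)[C@H](NC(=O)c1cc(Cl)ccc1O)C(=O)Nc1cccc(Cl)c1` likewise gives > 10000 nM in this assay, a limit. Compound 3 `CC(C)[C@@H](NC(=O)c1cc(Cl)ccc1O)C(=O)Nc1cccc(Cl)c1` likewise gives > 10000 nM in this assay, a limit. The step that the two limits leave unreadable from compound 2 to compound 3 thus stays unreadable despite (the fact that compounds 2 and 3 differ only in the configuration as drawn); what is known is the limit of > 10000 nM in this assay, at which 3 of the 3 values shown sit. Compound 4 `CC(C)[C@H](NC(=O)c1ccc(Cl)cc1O)C(=O)Nc1ccc(Cl)cc1` differs from compound 1 by chloro in place of bromo on an aromatic carbon. Going by the values given here, no measured step involves a chloro-for-bromo exchange, so nothing here quantifies this change, and the shared core has given nothing but limits. Compound 4 is therefore expected to remain at the limit, estimated at 15000 nM with a range of 5000 nM to 50000 nM. The expected step that the limit leaves unreadable from compound 1 to compound 4 is essentially none beyond the scatter.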

Compound 4, half-maximal inhibitory concentration: > 10000 nM
Compound 4 ended at the assay's limit; the forecaster's own chance of this, stated with the estimate: 85%; the middle value does not contradict the limit.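

No step can be read from compound 1 to compound 4, since both values are limits and not numbers: the limit of > 10000 nM in this assay, at which 4 of the 4 values shown sit. The compounds shown leave open whether any change to the shared core gives a measurable value in this assay.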